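Removing the remaining hydroxymethyl: clearance outlook for compound 4

A few compounds are considered here, and "the series" means these few. Any claim that something is new, unique, unknown or untested is made for them only; others in the source may bear on it.

compound 1, `Cc1nn2c(-c3c(C)nn(C)c3-c3ccc(C(F)(F)F)cc3)nc(CO)c2c(=O)[nH]1`, in an ADME assay on microsomes from liver (Homo sapiens) for metabolic stability (on this read-out higher numbers stand for fast clearance and lower numbers for slow clearance), reported only as a limit, < 8 mL/min/kg
compound 2, `Cc1nn2c(-c3c(CO)nn(C)c3-c3ccc(C(F)(F)F)cc3)nc(CO)c2c(=O)[nH]1`, in this assay reported only as a limit, < 9.2 mL/min/kg
compound 3, `Cc1nn2c(-c3c(CO)nn(C)c3-c3ccc(C(F)(F)F)cc3)nc(C)c2c(=O)[nH]1`, in this assay reported only as a limit, < 8 mL/min/kg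

Compound 3 stands at a limit, and the other two members of the series stand at limits as well, so no order among the three can be read from the numbers. The step that the two limits leave unreadable from compound 1 to compound 2 is unreadable, and so is a step that the two limits leave unreadable from compound 2 to compound 3; both rest on the limit of < 8 mL/min/kg in this assay, at which 2 of the 3 values shown sit, and the limit of < 9.2 mL/min/kg in this assay, at which 1 of the 3 values shown sits, and give no size for a hydroxy-for-hydrogen exchange in this series.

Compound 4, `Cc1nn2c(-c3c(C)nn(C)c3-c3ccc(C(F)(F)F)cc3)nc(C)c2c(=O)[nH]1`, differs from compound 3 by hydrogen in place of hydroxy on a saturated chain carbon bound to an aromatic carbon. Neither measured step bears readably on this change: in each of them a hydroxy was added or removed on a saturated chain carbon bound to an aromatic carbon without a number emerging on either side. The expectation for compound 4 rests only on the observation that every measured member sits at a limit, and the step of an at least 1.2-fold higher number from compound 3 to compound 4 (0.09 log units; that floor lies within the scatter) is estimated with wide bounds. Compound 4 is expected to give 10 mL/min/kg in this assay, within 4 mL/min/kg to 30 mL/min/kg, with a fair chance that it too comes back as a limit only.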

Compound 4, clearance: 16 mL/min/kg
For compound 4 the middle estimate is 1.6-fold (0.20 log units) below the measured one; the measured number falls inside the stated range.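

In this assay compound 4 is the only member shown that carries no hydroxymethyl, and it is also the only one that gives a number and not a limit. Hydrogen in place of hydroxy on a saturated chain carbon bound to an aromatic carbon now has a lower bound at each of the two places, an at least 2.0-fold higher number from compound 3 to compound 4 (0.30 log units; that floor lies within the scatter) at one and an at least 2.0-fold higher number from compound 1 to compound 4 (0.30 log units; that floor lies within the scatter) at the other, and since both floors lie within the scatter, neither establishes a real change by itself. Both steps remain floors and the true sizes may be larger, because compound 1 and compound 3 stand at a limit: the limit of < 8 mL/min/kg in this assay, at which 2 of the 4 values shown sit.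

The steps among the three hydroxymethyl compounds cannot be read, and the two floors do not tell which of the two places counts for more. Also open is how this assay would read with an amine, a carboxylic acid or a longer chain such as ethyl in place of methyl at either place, since the compounds shown carry only methyl or hydroxymethyl there.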